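Removing the Methoxy Group from a Chemokine Receptor Binder

This account rests on a few compounds, and the source may have more. Where it says the series, first, only, none or still open, it means among the compounds named here.

Compound 1 `COc1ccccc1C(=O)NCc1ccc(CNS(=O)(=O)c2ccccc2)cc1`: 1 nM
Compound 2 `COc1ccccc1C(=O)NCc1ccc(CNS(=O)(=O)c2ccc(C)cc2)cc1`: 100 nM

In an assay on MDA-MB-231 cells for binding affinity to C-X-C chemokine receptor type 4 (Homo sapiens), read by immunofluorescence and microscopy, with stated times of 10 min and 30 min (on this read-out higher numbers stand for an effect only at larger amounts of compound and lower numbers for an effect already at smaller amounts), compound 1 gives the lowest of the two numbers. Going by the values given here, the only measured step is a 100-fold higher number from compound 1 to compound 2 (2.00 log units; beyond the scatter), which comes from a methyl in place of hydrogen on an aromatic carbon at the sulfonamide end of the molecule. Compound 3 `O=C(NCc1ccc(CNS(=O)(=O)c2ccccc2)cc1)c1ccccc1` differs from compound 1 at the other end, by hydrogen in place of methoxy on an aromatic carbon. Among the compounds with values here, no measured step touches this part of the shared core, so the step to compound 3 cannot be read off directly; what the data show is that one small change elsewhere, in compound 2, was costly. A loss of some size is therefore expected, a 10-fold higher number from compound 1 to compound 3 (1.00 log units; beyond the scatter), though with wide uncertainty. For compound 3 the estimate in this assay is 10 nM, with a range from 1 nM to 100 nM.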

Compound 3, effective concentration (reported as EC, without a stated level of effect): 1 nM
Estimate against measurement, compound 3: 10-fold (1.00 log units) above; measured number inside the range.
By their numbers in this assay, from the lowest: compounds 1 and 3 (each within the scatter of the next); then compound 2.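

Taking the methoxy away gives no change at the digits printed from compound 1 to compound 3 (within the scatter) in this assay, so the 2-methoxyphenyl and phenyl versions cannot be told apart on this read-out. Going by these compounds alone, this end of the molecule therefore accepts the loss of 2 heavy atoms at a place ortho to a large group, whereas the one change at the sulfonamide end gave a 100-fold higher number from compound 1 to compound 2 (2.00 log units; beyond the scatter) and was far from neutral. Nothing available here explains why the methoxy can go without a shift in the number.

From the compounds shown here alone, it remains open whether a different group at this same place, such as an amine, a carboxylic acid or a longer chain like butoxy, would also leave the number unchanged. Going by these compounds, it is also open whether the added methyl at the sulfonamide end would carry the same cost on the phenyl version.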